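The source may hold more compounds than are shown below. What is called first, only, known or untested is meant among the compounds shown, and "the series" means these compounds.

Measured in a functional assay on LoVo cells (Homo sapiens) for cytotoxicity, read by MTT assay, with a stated time of 72 h; on this read-out higher numbers stand for weaker inhibition and lower numbers for stronger inhibition:

- Compound 1 `COc1cc(/C=C/C=O)cc(OC)c1OC/C=C(\C)CCC=C(C)C`: 23000 nM
- Compound 2 `CC(C)=CCOc1ccc(C(=O)/C=C/c2ccccc2)c(O)c1`: 58000 nM

Of these two compounds, compound 2 has the higher number, at 58000 nM, and so shows the weaker inhibition. Compound 1 stands at 23000 nM, and the gap between the two lies beyond the usual scatter of repeated measurements.

Compound 3 `CC(C)=CCOc1ccc(C(=O)/C=C/c2ccc(O)cc2)c(O)c1` differs from compound 2 in one place: hydroxy in place of hydrogen on an aromatic carbon. A hydroxy group takes the place of hydrogen on an aromatic carbon, para to a large group, so that phenyl becomes 4-hydroxyphenyl.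

Among the compounds with values here, no measured pair shows this change, so the data give no direct guide to its size or direction. Compound 1 and compound 2 differ in more than one place, and their gap cannot be carried over to this step. A small step towards a lower number is expected in this assay, probably not beyond the scatter, although a larger move in either direction cannot be ruled out. The expected change is a 1.7-fold lower number from compound 2 to compound 3 (0.22 log units; within the scatter). The estimate for compound 3 is 35000 nM, with an expected range of 14000 nM to 80000 nM.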

Compound 3, half-maximal inhibitory concentration: 57000 nM
Compound 3: middle estimate off by 1.6-fold (0.21 log units), on the low side; the measured number falls inside the stated range.
By their numbers in this assay, from the lowest: compound 1; then compounds 3 and 2 (each within the scatter of the next).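

In this assay, hydroxy in place of hydrogen on an aromatic carbon, para to a large group, turns phenyl into 4-hydroxyphenyl and gives a 1.0-fold lower number from compound 2 to compound 3 (0.01 log units; within the scatter). This is the first step among these compounds that differs in one place only, so the position can now be read directly instead of being left to a guess. At this position, in this cell assay, the added hydroxy leaves the 4-hydroxyphenyl compound indistinguishable from the phenyl compound, and nothing at hand accounts for that result.

The compounds shown leave open whether this position stays equally silent with other groups on the same aromatic carbon, such as methoxy, an amine or a carboxylic acid, or whether any of these would shift the number beyond the scatter. They also leave open whether hydroxy would behave the same way on a different core, such as that of compound 1, and whether a longer chain in place of the one on the ether oxygen of compound 2 would matter more than this change does.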